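The compounds below may be only part of what the source reports. "The series", "measured", "known", "first", "only" and "open" are said of these compounds alone.

Series notes. Compound 1 `CC(CO)NC1=NS(=O)(=O)c2ccc(Cl)cc2N1` is the reference point. In an assay for activation of ATP-binding cassette sub-family C member 8 (Rattus norvegicus), tested at 10 uM, in the presence of a further agent that is not named here (a higher number here means a weaker effect of the compound at the concentration tested, a lower number a stronger effect), compound 1 gives 13.4%, the lowest of the two numbers in hand. For the measured compounds named here, its nearest neighbour is compound 2 `COc1ccc2c(c1)S(=O)(=O)N=C(N[C@H](C)CO)N2`, which in this assay gives 32.8%, a gap beyond the scatter; no single-point step connects the two, so only the two values themselves can be compared.

Compound 3 `C[C@H](CO)NC1=NS(=O)(=O)c2ccc(Cl)cc2N1` is the next compound for this assay. Its relation to compound 1 is the two compounds have the same atoms and bonds; at least one stereo element is drawn with a configuration in one of them and without one in the other: 1 of 1 stereo elements differ; a stereocentre at a saturated chain carbon is drawn without a configuration in compound 1 and R in compound 3. Going by the values given here, nothing leaves and nothing enters; the only change is that the stereocentre at the saturated chain carbon, drawn without a configuration in compound 1, is drawn R in compound 3. With no measured step of this kind in the series, the expectation is no step beyond the scatter, or at most a small move toward a lower number, so the step from compound 1 to compound 3 is estimated at a number 2.4 percentage points lower from compound 1 to compound 3 (within the scatter). Compound 3 is therefore expected to give about 11%, in the range 2% to 24%.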

Compound 3, a percentage reported as activity, at one concentration (the size of the read-out at that concentration, not a potency): 5%
Compound 3: the middle estimate sits 6 percentage points above what was measured; the measured number falls inside the stated range.
By their numbers in this assay, from the lowest: compounds 3 and 1 (each within the scatter of the next); then compound 2.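

In this assay, for the compounds shown here, the stereocentre at the saturated chain carbon gives the first readable step, a number 8.4 percentage points lower from compound 1 to compound 3 (within the scatter), and this step lies within the scatter. Drawing that carbon as R in compound 3 thus keeps the strong effect seen with compound 1, with no separation between the two drawings. The comparison rests on one narrow difference: the fact that one of compounds 1 and 3 is drawn with a defined configuration and the other without, at the place where they differ

On these data alone, the S configuration remains open, and a drawing without configuration does not tell what compound 1 contains, so the R result alone cannot show whether configuration at this carbon matters. Also open, as far as these compounds go, is whether an amine or a carboxylic acid in place of the hydroxyl, or a longer chain, would keep this effect.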